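Swapping the aryl group on a weakly active core

The source may hold more compounds than are shown below. What is called first, only, known or untested is meant among the compounds shown, and "the series" means these compounds.

compound 1 `O=C1C(Nc2cccc(Cl)c2)=CC(=O)c2c1nc1n2[C@H]2OC[C@@H](O)[C@H]2OC1` — 7970 nM
compound 2 `O=C1C=C(NCc2ccccc2)C(=O)c2c1nc1n2[C@H]2OC[C@@H](O)[C@H]2OC1` — > 8000 nM

In a functional assay on HeLa cells (Homo sapiens) for inhibition, read by sulforhodamine B assay (on this read-out higher numbers stand for weaker inhibition and lower numbers for stronger inhibition), compound 1 gives 7970 nM, a weak result. For compound 2 the assay reports only a limit, > 8000 nM, and not a number. Going by the values given here, compound 1 therefore holds the only number in hand, and the other value sits at the limit of > 8000 nM in this assay, at which 1 of the 2 values shown sits. Compound 3 `CCOc1ccc(NC2=CC(=O)c3c(nc4n3[C@H]3OC[C@@H](O)[C@H]3OC4)C2=O)cc1` differs from compound 1 in one place: 4-ethoxyphenyl in place of 3-chlorophenyl on an amine nitrogen. Among the compounds with values here, no measured pair shows how such a change shifts the result, so the expectation rests on compound 1 and its 7970 nM alone. The step in this assay from compound 1 to compound 3 is expected to be small, a 1.0-fold higher number from compound 1 to compound 3 (0.00 log units; within the scatter), with no direction beyond the usual scatter. Compound 3 is thus estimated at 8000 nM, somewhere between 3000 nM and 20000 nM, with a fair chance that the assay returns only a limit.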

Compound 3, half-maximal inhibitory concentration: 14400 nM
Estimate against measurement, compound 3: 1.8-fold (0.26 log units) below; low and high end bracket the measured number.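

The aryl group on the amine nitrogen now has its first measured step: in this assay, putting 4-ethoxyphenyl in place of 3-chlorophenyl gives a 1.8-fold higher number from compound 1 to compound 3 (0.26 log units; within the scatter). These two aryl groups therefore cannot be told apart on this read-out, and neither one turns the shared core into a strong inhibitor. Compound 2 gives only a limit and adds no step: the limit of > 8000 nM in this assay, at which 1 of the 3 values shown sits.

As far as these compounds go, it remains open whether a group of another kind on this nitrogen, such as a pyridine ring, a short alkyl chain or a phenyl ring carrying a carboxylic acid, would shift the result beyond the usual scatter. From the compounds shown here alone, it also remains open whether a change elsewhere on the shared core would move the number more than this swap of aryl groups did.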